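Aryl sulfonamide series: working notes towards compound 3

The compounds below may be only part of what the source reports. "The series", "measured", "known", "first", "only" and "open" are said of these compounds alone.

Measured so far:
compound 1 `C=Cc1ccc(S(=O)(=O)Nc2ccc3oc(-c4ccccc4)nc3c2)cc1` — > 100000 nM
compound 2 `O=S(=O)(Nc1ccc(-c2nc3cc(NS(=O)(=O)c4cccc(O)c4)ccc3o2)cc1)c1cccc(O)c1` — 17000 nM

Both were run in an assay on cells for inhibition of HSP60/HSP10 (Homo sapiens), with a stated time of 60 min; on this read-out lower numbers stand for stronger inhibition and higher numbers for weaker inhibition. For compound 1 the value > 100000 nM is a limit of the assay and not a number. Compound 2 gives 17000 nM. Within the data shown here, compound 1 therefore stands only at the reporting boundary, described by the limit of > 100000 nM in this assay, at which 1 of the 2 values shown sits; no step between measured compounds is available, and the pair compound 1 and compound 2 shows no more than its two values.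

Compound 3 `O=S(=O)(Nc1ccc2oc(-c3ccccc3)nc2c1)c1ccccc1F` is still to be measured. Relative to compound 1 it carries 2-fluorophenyl in place of 4-vinylphenyl on a sulfonyl sulfur, with the rest of the structure unchanged. Since compound 1 sits at a limit, the step cannot be anchored in measured data. The step of an at least 1.2-fold lower number from compound 1 to compound 3 (0.09 log units; that floor lies within the scatter) is expected to stay within the usual scatter, with no settled direction. Compound 3 is estimated at 80000 nM, with a range from 15000 nM to 300000 nM, and a fair chance that only a limit is reported again.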

Compound 3, half-maximal inhibitory concentration: > 100000 nM
Compound 3 was reported as a limit (the forecaster's own chance of this, stated with the estimate: 60%); middle value at least 1.2-fold (0.09 log units) away from the limit.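

Compound 3, like compound 1, is reported in this assay only as a limit, so no step between the two can be read: the limit of > 100000 nM in this assay, at which 2 of the 3 values shown sit.

The compounds shown leave open whether 2-fluorophenyl in place of 4-vinylphenyl on a sulfonyl sulfur changes the read-out at all.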